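One Ring Stereocentre Inverted in a Weakly Active Series

A few compounds are considered here, and "the series" means these few. Any claim that something is new, unique, unknown or untested is made for them only; others in the source may bear on it.

In a functional assay on RCC4 cells (Homo sapiens) for antiproliferative activity, read by XTT assay, with a stated time of 48 h (on this read-out lower numbers stand for stronger inhibition and higher numbers for weaker inhibition), compound 1 `COc1cccc(N(Cc2cn([C@@H]3O[C@H](COC(C)=O)[C@@H](OC(C)=O)[C@H](OC(C)=O)[C@H]3OC(C)=O)nn2)S(C)(=O)=O)c1` gives 200000 nM and compound 2 `CC(=O)OC[C@H]1O[C@@H](n2cc(CN(c3ccc(C#N)cc3)S(C)(=O)=O)nn2)[C@H](OC(C)=O)[C@@H](OC(C)=O)[C@@H]1OC(C)=O` gives 120000 nM. With a 1.7-fold lower number from compound 1 to compound 2 (0.22 log units; within the scatter), compound 2 stands level with compound 1. Compound 3 `COC(=O)CN(Cc1cn([C@@H]2O[C@H](COC(C)=O)[C@@H](OC(C)=O)[C@H](OC(C)=O)[C@H]2OC(C)=O)nn1)S(C)(=O)=O` reaches only a limit of the assay, > 250000 nM. Against that limit, an at least 2.0-fold higher number from compound 2 to compound 3 (0.31 log units; beyond the scatter), so compound 2 is separated from compound 3. Compound 4 `CC(=O)OC[C@H]1O[C@@H](n2cc(CN(c3ccc(C#N)cc3)S(C)(=O)=O)nn2)[C@H](OC(C)=O)[C@@H](OC(C)=O)[C@H]1OC(C)=O` keeps the atoms and bonds of compound 2: the two compounds have the same atoms and bonds and differ only in configuration as drawn: 1 of 5 stereo elements differ; a stereocentre at a saturated ring carbon is drawn R in compound 2 and S in compound 4. All measured steps change the group on the sulfonamide nitrogen and none changes configuration, so none bears directly on this change. Without such a measurement, the expected result is a 1.1-fold higher number from compound 2 to compound 4 (0.03 log units; within the scatter), with no change beyond the scatter. Compound 4 is estimated at 130000 nM, with an expected range of 60000 nM to 250000 nM.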

Compound 4, half-maximal inhibitory concentration: 170000 nM
For compound 4 the middle estimate is 1.3-fold (0.12 log units) below the measured one; measured number inside the range.
By their numbers in this assay, from the lowest: compounds 2, 4 and 1 (each within the scatter of the next). At a limit, above all of these: compound 3.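

In this assay, inverting this one ring stereocentre gives a 1.4-fold higher number from compound 2 to compound 4 (0.15 log units; within the scatter), so compound 2 and compound 4 stand level. This is the first step in the series that leaves the group on the sulfonamide nitrogen untouched, and it isolates configuration at this saturated ring carbon: the fact that compounds 2 and 4 differ only in the configuration as drawn

The compounds shown leave open whether inverting the other ring stereocentres would read the same way, or whether the same inversion would with another group on the sulfonamide nitrogen. They also leave open what free hydroxyl groups in place of the acetate esters on the shared core would give.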